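A Third Isopropyl on the Sulfonate Ring

The source may report more compounds than this note shows. Statements on the series, on what has been measured and on what is new or still open speak of the compounds shown alone.

Two measured compounds share a core and differ only in the atom that links the sulfonyl group to the second aryl ring. Compound 1 `CC(C)c1cccc(C(C)C)c1NC(=O)CS(=O)(=O)Nc1c(C(C)C)cccc1C(C)C` carries a sulfonamide there, and in an assay on microsomes from intestine for inhibition of acyl-CoA:cholesterol acyltransferase (Oryctolagus cuniculus) (on this read-out lower numbers stand for stronger inhibition and higher numbers for weaker inhibition), compound 1 gives 350 nM. Compound 2 `CC(C)c1cccc(C(C)C)c1NC(=O)CS(=O)(=O)Oc1c(C(C)C)cccc1C(C)C` carries a sulfonate ester instead, and in this assay compound 2 gives 7 nM. Compound 2 thus has the lower of the two numbers, and its gap to compound 1 lies beyond the usual scatter.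

Compound 3 `CC(C)c1cc(C(C)C)c(OS(=O)(=O)CC(=O)Nc2c(C(C)C)cccc2C(C)C)c(C(C)C)c1` is not yet measured. It differs from compound 2 by isopropyl in place of hydrogen on an aromatic carbon, meta to two isopropyl groups and para to a large group. Going by the values given here, no measured pair shows this change, so no step beyond the scatter is expected in either direction. Compound 3 is estimated at 7 nM, between 2 nM and 25 nM, which means a step of no change at the digits printed from compound 2 to compound 3 (within the scatter).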

Compound 3, half-maximal inhibitory concentration: 7 nM
Compound 3: the middle estimate sits on the measured number at the digits printed; low and high end bracket the measured number.
By their numbers in this assay, from the lowest: compounds 2 and 3 (each within the scatter of the next); then compound 1.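

In this assay the isopropyl that enters, meta to two isopropyl groups and para to a large group, brings no change at the digits printed from compound 2 to compound 3 (within the scatter). Going by these compounds alone, this position on the six-membered aromatic ring of carbon only therefore takes a group of 3 heavy atoms in place of hydrogen with no step beyond the scatter, something the earlier compounds could not show, as they differ only in the atom linking the sulfonyl group to the second aryl ring. Nothing available explains this result.

The compounds shown leave open whether an amine, a carboxylic acid or a longer chain at this position would give the same reading. They also leave open whether isopropyl in place of hydrogen here would give the same step on the sulfonamide of compound 1.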